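This account rests on a few compounds, and the source may have more. Where it says the series, first, only, none or still open, it means among the compounds named here.

Compound 3 `COc1ccc(C2CC(c3ccccc3)=NN2C2=NC(=O)/C(=C3\C(=O)Nc4ccc(Br)cc43)S2)cc1` was tested in a functional assay on cells (Cancer cell lines, Homo sapiens) for cytotoxicity, read by sulforhodamine B assay, with a stated time of 48 h (on this read-out higher numbers stand for weaker inhibition of growth and lower numbers for stronger inhibition of growth), where compound 3 gives 510 nM. Compound 1 `O=C1N=C(N2N=C(c3ccccc3)CC2c2ccccc2O)S/C1=C1/C(=O)Nc2ccc(Br)cc21` gives 670 nM in this assay, and the step of a 1.3-fold lower number from compound 1 to compound 3 (0.12 log units; within the scatter) is one that repeated testing could blur. Compound 2 `COc1ccc(C2CC(c3ccccc3)=NN2C2=NC(=O)/C(=C3\C(=O)Nc4ccccc43)S2)cc1` gives 6040 nM, and the step of a 12-fold lower number from compound 2 to compound 3 (1.07 log units; beyond the scatter) stands well clear of the scatter. Compound 4 `COc1ccc(C2CC(c3ccc4ccccc4c3)=NN2C2=NC(=O)/C(=C3\C(=O)Nc4ccc(Br)cc43)S2)cc1` differs from compound 3 by naphthalen-2-yl in place of phenyl on a carbon with a double bond to nitrogen. Neither measured step involves this carbon: one swaps the group on a saturated ring carbon, the other puts bromo on an aromatic carbon, so no measured comparison bears directly on the change. With aromatic rings of carbon only leaving and entering, no step beyond the scatter is expected. Compound 4 is therefore estimated at 450 nM, with a range from 150 nM to 1400 nM. The estimated shift is a 1.1-fold lower number from compound 3 to compound 4 (0.05 log units; within the scatter).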

Compound 4, concentration for total growth inhibition: 220 nM
Compound 4: the middle estimate sits 2.0-fold (0.31 log units) above what was measured, within the range that was stated.
By their numbers in this assay, from the lowest: compound 4; then compounds 3 and 1 (each within the scatter of the next); then compound 2.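

Swapping phenyl for naphthalen-2-yl on this carbon with a double bond to nitrogen gives a 2.3-fold lower number from compound 3 to compound 4 (0.37 log units; beyond the scatter) in this assay and is a modest step. Going by these compounds alone, it is the first measured change at this carbon, and it shows that the number responds to the group here and that a second six-membered aromatic ring does not weaken growth inhibition. No measurement at hand accounts for this shift. Still open, as far as these compounds go, is whether a non-aromatic group at this carbon, such as an amine or a longer chain, would hold this number. Also open, from the compounds shown here alone, is whether the gain persists without the bromo group.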